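The compounds below may be only part of what the source reports. "The series", "measured", "known", "first", "only" and "open" are said of these compounds alone.

Compound 1 `CCOC(=O)C1=C(N/N=C(/C#N)C(=O)OCC)Nc2[nH]nc(C)c2C1c1ccc(N(C)C)cc1`: 46400 nM
Compound 2 `CCOC(=O)C1=C(N/N=C(\C#N)C(N)=O)Nc2[nH]nc(C)c2C1c1ccc(N(C)C)cc1`: 48400 nM
Compound 3 `CCOC(=O)C1=C(N/C=N/c2ncc(-c3ccccc3)s2)Nc2[nH]nc(C)c2C1c1ccc(N(C)C)cc1`: 9790 nM

In a functional assay on HepG2 cells (Homo sapiens) for inhibition, read by MTT assay, with a stated time of 48 h (on this read-out higher numbers stand for weaker inhibition and lower numbers for stronger inhibition), compound 3 gives the lowest of the three numbers, and compound 1 and compound 2 both stand higher. Compound 4 `CCOC(=O)C1=C(N/C=N/c2ccc(C)cc2)Nc2[nH]nc(C)c2C1c1ccc(N(C)C)cc1` keeps the shared core and differs from compound 3 as follows: 4-methylphenyl in place of 5-phenyl-1,3-thiazol-2-yl on a double-bonded nitrogen. In words, 4-methylphenyl stands in place of 5-phenyl-1,3-thiazol-2-yl on a double-bonded nitrogen. Going by the values given here, the only measured step, a 1.0-fold higher number from compound 1 to compound 2 (0.02 log units; within the scatter), concerns another group on an amine nitrogen, so it bears on this change only weakly. Among the compounds with values here, no measured step alters the group on the double-bonded nitrogen. With compound 3 lowest at 9790 nM, a modest move to a higher number is expected, and the expected step is a 1.5-fold higher number from compound 3 to compound 4 (0.19 log units; within the scatter). Compound 4 is estimated at 15000 nM, with an expected range of 5000 nM to 45000 nM.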

Compound 4, half-maximal inhibitory concentration: 44400 nM
The estimate for compound 4 lay 3.0-fold (0.47 log units) below the measured number, within the range that was stated.
By their numbers in this assay, from the lowest: compound 3; then compounds 4, 1 and 2 (each within the scatter of the next).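

In this assay, going by these compounds alone, 4-methylphenyl in place of 5-phenyl-1,3-thiazol-2-yl on a double-bonded nitrogen gives a 4.5-fold higher number from compound 3 to compound 4 (0.66 log units; beyond the scatter), the first measured change at this group, and it lies beyond the scatter. The steps of a 1.1-fold lower number from compound 2 to compound 4 (0.04 log units; within the scatter) and a 1.0-fold lower number from compound 1 to compound 4 (0.02 log units; within the scatter) stay within the scatter, so among these compounds only the one carrying 5-phenyl-1,3-thiazol-2-yl stands apart. No evidence is available to explain this difference.

As far as these compounds go, it remains open whether the thiazole ring or its phenyl carries the difference, and whether a plain 1,3-thiazol-2-yl or a 4-aminophenyl would give a number nearer that of compound 3.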